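From a methylphenyl group to a pyridyl group

A few compounds are considered here, and "the series" means these few. Any claim that something is new, unique, unknown or untested is made for them only; others in the source may bear on it.

Three related compounds have been tested in a functional assay on MDA-MB-231 cells (Homo sapiens) for antiproliferative activity, read by MTT assay, with a stated time of 24 h; a higher number here means a weaker inhibitor, a lower number a stronger inhibitor. Compound 1 `CC(C)(C)c1ccc(-c2cn(C/C=C3\OC(=O)C(OCc4ccccc4)=C3OCc3ccccc3)nn2)cc1` carries a tert-butyl group on its outer aromatic ring, and in this assay compound 1 gives 51200 nM. Compound 2 `O=C1NC(O)(CCn2cc(-c3ccccc3)nn2)C(OCc2ccccc2)=C1OCc1ccccc1` has a differently built core, and in this assay compound 2 gives 21100 nM. Compound 3 `Cc1ccc(-c2cn(C/C=C3\OC(=O)C(OCc4ccccc4)=C3OCc3ccccc3)nn2)cc1` is compound 1 with methyl in place of tert-butyl on that aromatic carbon. For compound 3 the assay reports only a limit, > 100000 nM, not a number. The step of an at least 1.9-fold higher number from compound 1 to compound 3 (0.29 log units; that floor lies within the scatter) therefore cannot be pinned down, and compound 3 stands at the edge of what this assay can report, namely (the limit of > 100000 nM in this assay, at which 1 of the 3 values shown sits).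

Compound 4 `O=C1O/C(=C\Cn2cc(-c3ccccn3)nn2)C(OCc2ccccc2)=C1OCc1ccccc1` differs from compound 3 by pyridin-2-yl in place of 4-methylphenyl on an aromatic carbon. Among the measured compounds shown here, none of the measured steps exchanges one aromatic ring for another; the only measured step, an at least 1.9-fold higher number from compound 1 to compound 3 (0.29 log units; that floor lies within the scatter), changes an alkyl group and has a floor that lies within the scatter, so it offers little guidance for this ring swap. Compound 4 is thus expected to sit close to where compound 3 stands, with a fair chance that the assay again reports only a limit. For compound 4 the estimated value is 80000 nM, with a range from 30000 nM to 200000 nM. That estimate corresponds to an expected step of an at least 1.2-fold lower number from compound 3 to compound 4 (0.09 log units; that floor lies within the scatter).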

Compound 4, half-maximal inhibitory concentration: > 100000 nM
Compound 4 ended at the assay's limit (the forecaster's own chance of this, stated with the estimate: 50%); at least 1.2-fold (0.09 log units) between middle value and limit.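

In this assay compound 4 gives > 100000 nM, which is a limit and not a number. Placing a nitrogen in the outer ring, as pyridin-2-yl in place of 4-methylphenyl, therefore does not bring the series back into the readable range, and with limits on both sides the step between these two compounds cannot be read: the limit of > 100000 nM in this assay, at which 2 of the 4 values shown sit. The one step that can be read is an at least 1.9-fold higher number from compound 1 to compound 4 (0.29 log units; that floor lies within the scatter), where pyridin-2-yl replaces 4-(tert-butyl)phenyl; it gives only a floor, and because that floor lies within the scatter, it does not establish a real gap.

The compounds shown leave open whether an amine or a carboxylic acid on the outer ring would give a measurable number in this assay rather than another limit. Going by these compounds, it also remains open how pyridin-2-yl would behave on the core of compound 2, which gives 21100 nM with a plain phenyl ring at the corresponding place.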